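A Chain Swap on a Shared Core for Compound 4

The source may report more compounds than this note shows. Statements on the series, on what has been measured and on what is new or still open speak of the compounds shown alone.

Three compounds have been measured in a functional assay on CHO cells for agonist activity at Free fatty acid receptor 1 (Rattus norvegicus), read by calcium flux; a higher number here means that more compound is needed for the effect, a lower number that less compound is needed:
- compound 1, `Cc1cccc(C)c1-c1cccc(COc2ccc(CCC(=O)O)nc2)c1`, gives 210 nM
- compound 2, `Cc1cccc(C)c1-c1cccc(COc2ccc(CCC(=O)O)nn2)c1`, gives 310 nM
- compound 3, `Cc1cccc(C)c1-c1cccc(COc2ccc(CC(F)C(=O)O)cn2)c1`, gives 250 nM

Compound 3 holds the second highest of these three numbers. Its gap to compound 1, the nearest, and its gap to compound 2, the furthest, both fall within the usual scatter, so the three compounds cannot be ranked against one another on these numbers.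

Compound 4, `CCOC(CC(=O)O)c1ccc(OCc2cccc(-c3c(C)cccc3C)c2)nc1`, keeps the shared core of compound 3 and changes only the chain: 2-carboxy-1-ethoxyethyl in place of 2-carboxy-2-fluoroethyl on an aromatic carbon. Among the compounds with values here, no pair of measured compounds differs in a single place, so no measured step can be read across to this change. What the three measured compounds do show is that variations in the ring nitrogens and in the chain have left this assay essentially unmoved. The expected step is a 1.2-fold higher number from compound 3 to compound 4 (0.08 log units; within the scatter), estimated to stay within the scatter rather than move in either direction. Compound 4 is therefore estimated at 300 nM, with a range from 100 nM to 900 nM.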

Compound 4, half-maximal effective concentration: 130 nM
Beside the measured number, compound 4's estimate is 2.3-fold (0.36 log units) above it; low and high end bracket the measured number.
By their numbers in this assay, from the lowest: compounds 4, 1, 3 and 2 (each within the scatter of the next, the first and the last beyond it).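

Within the data shown here, the step of a 1.9-fold lower number from compound 3 to compound 4 (0.28 log units; within the scatter) is the first reading in this assay between two compounds that differ in one place only. It shows that, on this aromatic carbon, two atoms from the ring nitrogen and para to a large group, 2-carboxy-1-ethoxyethyl can take the place of 2-carboxy-2-fluoroethyl without the number leaving the scatter, even though the entering chain has 8 heavy atoms against 6 and one more hydrogen-bond acceptor. The exchange of fluorine for an ethoxy group, placed on a different carbon of the chain, therefore registers as no clear change here.

On these data alone, whether a methoxy group, a propoxy group or an amine on this chain would behave in the same way remains open, as does the effect of the ethoxy chain on the cores of compound 1 and compound 2. Nothing available explains why this exchange leaves the number within the scatter.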